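This account rests on a few compounds, and the source may have more. Where it says the series, first, only, none or still open, it means among the compounds named here.

In a physicochemical assay for solubility, read by LC-MS, in phosphate buffer, with a stated time of 24 h, at pH 7.4 (on this read-out higher numbers stand for higher solubility and lower numbers for lower solubility), compound 1 `O=C(Nc1ccccc1)c1cnc(NCc2c(F)ccc3c2CCO3)n2cnnc12` gives only a limit, < 1000 nM. Compound 2 `Cc1ncccc1-c1cnc(NCc2c(F)ccc3c2CCO3)c2ncc(=O)[nH]c12` reads 29000 nM. Compound 3 `Cc1nc(CN(C)C)ccc1-c1cnc(NCc2c(F)ccc3c2CCO3)c2cn[nH]c(=O)c12` also gives only a limit, > 1000000 nM. Going by these compounds, compound 1 therefore sits at the low end of these three results, although its exact value remains unknown.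

Compound 4 `CN(c1ccccc1)c1cnc(NCc2c(F)ccc3c2CCO3)n2cnnc12` has not yet been measured. It carries methyl(phenyl)amino in place of the phenylcarbamoyl of compound 1 on an aromatic carbon, (methyl(phenyl)amino in place of phenylcarbamoyl on an aromatic carbon). Within the data shown here, compound 2 and compound 3 differ from compound 1 in more than one place, so no measured pair isolates this change. Compound 4 shares its core with compound 1, whose limit of < 1000 nM anchors the expectation. Only a modest upward move is expected in this assay, with an estimated at least 1.5-fold higher number from compound 1 to compound 4 (0.17 log units; that floor lies within the scatter), and another result reported only as a limit would be no surprise. The value expected for compound 4 is an estimated 1500 nM, within a range from 200 nM to 10000 nM.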

Compound 4, solubility: < 2000 nM
Compound 4: only a limit was reported; the forecaster's own chance of this, stated with the estimate: 50%; the middle value does not contradict the limit.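

In this assay compound 4 gives < 2000 nM, which is a limit. Compound 1 gives < 1000 nM, also a limit, so no step can be read between these two compounds. Going by these compounds, what remains open is whether methyl(phenyl)amino in place of phenylcarbamoyl changes the solubility read-out at all, and in which direction.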